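The compounds below may be only part of what the source reports. "The series", "measured", "known", "first", "only" and "open" are said of these compounds alone.

In an assay on isolated protein with Bile acid receptor (Homo sapiens) as the target (a higher number here means that more compound is needed for the effect, a lower number that less compound is needed), compound 1 `COC(=O)/C=C/c1cccc(N(Cc2ccc(/C=C/c3cc(C(F)(F)F)cc(C(F)(F)F)c3)cc2)C(=O)C(C)C)c1` gives 1950 nM, compound 2 `COC(=O)/C=C/c1cccc(N(Cc2ccc(/C=C/c3cccc(C(F)(F)F)c3)cc2)C(=O)C(C)C)c1` gives 267 nM, and compound 3 `COC(=O)/C=C/c1cccc(N(Cc2ccc(/C=C/c3ccc(F)cc3)cc2)C(=O)NC(C)C)c1` gives 348 nM. Compound 2 has the lowest of these three numbers, though its number and that of compound 3 lie within the scatter of each other. Compound 4 `CCOc1cccc(-c2ccc(CN(C(=O)C(C)C)c3cccc(/C=C/C(=O)OC)c3)cc2)c1` differs from compound 2 by 3-ethoxyphenyl in place of 2-(3-(trifluoromethyl)phenyl)ethenyl on an aromatic carbon. Among the compounds with values here, the only measured step in this region of the molecule is a 7.3-fold lower number from compound 1 to compound 2 (0.86 log units; beyond the scatter), where removing one trifluoromethyl lowered the number; no measured step swaps the whole side group as here, so the guide is weak. A modestly higher number is expected for compound 4 in this assay, with an estimate of 650 nM, between 150 nM and 2800 nM. This estimate means an expected step of a 2.4-fold higher number from compound 2 to compound 4 (0.39 log units; beyond the scatter).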

Compound 4, half-maximal effective concentration: 173 nM
Estimate against measurement, compound 4: 3.8-fold (0.57 log units) above, within the range that was stated.
By their numbers in this assay, from the lowest: compounds 4, 2 and 3 (each within the scatter of the next); then compound 1.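

Exchanging the whole side group in this assay gives a 1.5-fold lower number from compound 2 to compound 4 (0.19 log units; within the scatter) and so leaves the number within the scatter. Within the data shown here, this position therefore tolerates 3-ethoxyphenyl as well as 2-(3-(trifluoromethyl)phenyl)ethenyl, showing that neither the double bond outside the rings nor a trifluoromethyl is required, something the earlier compounds, which all carry both an ethenyl link and a ring at this position, could not show. No measurement shown explains this tolerance. Still open, on these data alone, is how an amine, a carboxylic acid or a longer chain in place of the ethoxy group would fare.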